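The compounds below may be only part of what the source reports. "The series", "measured", "known", "first", "only" and "open" are said of these compounds alone.

Measured so far:
compound 1, `CN1CC[N+](C)(CCCCCCCOc2ccc(-n3cc(C(=O)Nc4cc(F)cc(F)c4)c(=O)c4ccc(N(C)C)nc43)cc2Cl)CC1`, 15.4%
compound 2, `Cc1cc(OCCCCCCC[N+]2(C)CCN(C)CC2)cc(-n2cc(C(=O)Nc3cc(F)cc(F)c3)c(=O)c3ccc(N(C)C)nc32)c1`, 38.2%
compound 3, `CC[N+]1(CCCCCCCOc2ccc(-n3cc(C(=O)Nc4cc(F)cc(F)c4)c(=O)c4ccc(N(C)C)nc43)cc2Cl)CCCC1`, 23.5%

In an assay on LX2 cells for inhibition of COL1A1 promoter (Homo sapiens), read by a luciferase reporter, with a stated time of 24 h, tested at 50 uM (a higher number here means a stronger effect of the compound at the concentration tested, a lower number a weaker effect), compound 2 stands highest of the three, with compound 3 next and compound 1 furthest behind. Compound 1 and compound 3 share a core and differ by one change, (a group of 7 heavy atoms (6 carbon, 1 nitrogen; one five-membered non-aromatic ring with 1 hetero atom) in place of a group of 8 heavy atoms (6 carbon, 2 nitrogen; one six-membered non-aromatic ring with 2 hetero atoms), on a saturated chain carbon, seven bonds along the chain from an oxygen on an aromatic ring), which made a step of a number 8.1 percentage points higher from compound 1 to compound 3 (within the scatter). The difference between the core of compound 1 and the core of compound 2 is not broken down here.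

Compound 4, `CC[N+]1(CCCCCCCOc2cc(C)cc(-n3cc(C(=O)Nc4cc(F)cc(F)c4)c(=O)c4ccc(N(C)C)nc43)c2)CCCC1`, is not yet measured. It arises from compound 2 by the same change, (a group of 7 heavy atoms (6 carbon, 1 nitrogen; one five-membered non-aromatic ring with 1 hetero atom) in place of a group of 8 heavy atoms (6 carbon, 2 nitrogen; one six-membered non-aromatic ring with 2 hetero atoms), on a saturated chain carbon, seven bonds along the chain from an oxygen on an aromatic ring). Since compound 1 to compound 3 moved only within the scatter, the step from compound 2 to compound 4 in this assay is expected to be of similar size, a number 4.8 percentage points higher from compound 2 to compound 4 (within the scatter). Compound 4 is therefore estimated at 43%, with a range from 28% to 58%.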

Compound 4, a percentage reported as inhibition, at one concentration (the size of the read-out at that concentration, not a potency): 73.2%
Estimate against measurement, compound 4: 30.2 percentage points below; the measured number lies above the stated range.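

In this assay, putting the group with the five-membered ring in place of the group with the six-membered ring gave a number 35 percentage points higher from compound 2 to compound 4 (beyond the scatter), so on these two cores the change did not carry over at one size: the same change on two cores in this assay, a number 8.1 percentage points higher (within the scatter) from compound 1 to compound 3 and a number 35 percentage points higher (beyond the scatter) from compound 2 to compound 4, 26.9 percentage points apart, beyond the scatter of two such steps On the core of compound 1 the step cannot be told from scatter, whereas on the core of compound 2 it is large. These two pairs do not show which difference between the cores accounts for this, nor what the change would do on any further core.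

As far as these compounds go, whether a morpholine or an uncharged tertiary amine at the end of the chain, or a shorter or longer chain, would follow either step remains open. From the compounds shown here alone, the read-out also comes from a single concentration, so it shows a stronger effect for compound 4 than for compound 2 at that concentration only, and the effect at other concentrations remains open.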